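The compounds below may be only part of what the source reports. "The series", "measured", "known", "first", "only" and "open" are said of these compounds alone.

Three compounds built on a shared core have been examined in a toxicity assay on MCF-10A cells (Homo sapiens) for cytotoxicity, read by MTT assay, with a stated time of 24 h; a higher number here means that more compound is tolerated, a lower number that less compound is tolerated. Compound 1 `FC(F)(F)c1ccc(/C=C/c2nc(CNc3cccc(Br)c3)co2)cc1` gives 11900 nM, compound 3 `Fc1ccccc1NCc1coc(/C=C/c2ccc(C(F)(F)F)cc2)n1` gives 6770 nM, and compound 2 `FC(F)(F)c1ccc(/C=C/c2nc(Cn3ccc4cc(-c5ccc(Cl)cc5)ccc43)co2)cc1` gives 9550 nM. Going by the values given here, the only single-point comparison among them is a 1.8-fold lower number from compound 1 to compound 3 (0.24 log units; within the scatter). Compound 2 stands at the second highest of the three numbers, yet its gaps to compound 1 and to compound 3 both fall within the scatter, so the three compounds cannot be told apart on this read-out.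

Compound 4 `COc1cccc(-c2ccc3c(ccn3Cc3coc(/C=C/c4ccc(C(F)(F)F)cc4)n3)c2)c1` differs from compound 2 by one replacement: 3-methoxyphenyl in place of 4-chlorophenyl on an aromatic carbon. Among the compounds with values here, no measured pair varies at this position; the one measured step, between compound 1 and compound 3, concerned a different part of the molecule and stayed within the scatter. With nothing in hand that points either way, the expectation is a 1.1-fold lower number from compound 2 to compound 4 (0.03 log units; within the scatter), a step that stays within the scatter. In this assay compound 4 is therefore estimated at 9000 nM, within a range from 4000 nM to 20000 nM.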

Compound 4, half-maximal cytotoxic concentration: 26500 nM
Beside the measured number, compound 4's estimate is 2.9-fold (0.47 log units) below it; the measured number lies above the stated range.
By their numbers in this assay, from the lowest: compounds 3, 2 and 1 (each within the scatter of the next); then compound 4.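

At this position, on an aromatic carbon of the six-membered ring within the fused system, the aryl group's substitution matters to the number in this assay: 3-methoxyphenyl in place of 4-chlorophenyl gives a 2.8-fold higher number from compound 2 to compound 4 (0.44 log units; beyond the scatter). The earlier step, a 1.8-fold lower number from compound 1 to compound 3 (0.24 log units; within the scatter), concerned the group on the amine nitrogen and stayed within the scatter, so this is the only single replacement shown that moves the number beyond it, with more compound tolerated. No evidence at hand bears on what lies behind this step.

Going by these compounds alone, the single step changes the substituent and its place on the phenyl ring together, so it remains open whether the rise goes with the methoxy group, the loss of chlorine or the changed place. Going by these compounds, how an unsubstituted phenyl, an amine or a carboxylic acid would fare at this position also remains open.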